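A few compounds are considered here, and "the series" means these few. Any claim that something is new, unique, unknown or untested is made for them only; others in the source may bear on it.

Four compounds share one core and differ in the chain attached to it. Compound 2 `COCCOCCOCCOCCOCCOCCOC(=O)Oc1c(C(C)C)cccc1C(C)C` gives 830 ug/mL in a physicochemical assay for solubility, in phosphate buffer, at pH 7.4; a lower number here means a less soluble compound, a higher number a more soluble compound. Compound 3 `COCCOCCOCCOCCOCCOCCOCC(=O)Oc1c(C(C)C)cccc1C(C)C` is built on a core that differs from that of compound 2; the difference between the two cores is not broken down here. In this assay compound 3 gives 2020 ug/mL, the highest of the two numbers. Compound 1 `COCCOCCOCCOCCOCCOCCOCCOCCOCCOCCOC(=O)Oc1c(C(C)C)cccc1C(C)C` differs from compound 2 by a group of 12 heavy atoms (8 carbon, 4 oxygen; no ring) in place of a hydrogen atom, on a saturated chain carbon bound to an oxygen on a saturated carbon. In this assay compound 1 reaches a limit of the measurement and gives > 314000 ug/mL. The step of an at least 370-fold higher number from compound 2 to compound 1 (2.57 log units; beyond the scatter) is therefore known only through (the limit of > 314000 ug/mL in this assay, at which 1 of the 3 values shown sits), as a lower bound and not a number.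

Compound 4 `COCCOCCOCCOCCOCCOCCOCCOCCOCCOCCOCC(=O)Oc1c(C(C)C)cccc1C(C)C`, still to be measured, stands to compound 3 as compound 1 stands to compound 2: the change is a group of 12 heavy atoms (8 carbon, 4 oxygen; no ring) in place of a hydrogen atom, on a saturated chain carbon bound to an oxygen on a saturated carbon, the same change at the same place. Compound 4 is expected to show a step of a 200-fold higher number from compound 3 to compound 4 (2.30 log units; beyond the scatter) from compound 3, resting on the step of an at least 370-fold higher number from compound 2 to compound 1 (2.57 log units; beyond the scatter) made by the same change. Compound 4 is thus estimated at 400000 ug/mL, most likely reported again only as a limit.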

Compound 4, solubility: > 371000 ug/mL
Compound 4 was reported as a limit; the forecaster's own chance of this, stated with the estimate: 75%; the middle value does not contradict the limit.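

In this assay the same group of 12 heavy atoms (8 carbon, 4 oxygen; no ring) in place of a hydrogen atom gives an at least 180-fold higher number from compound 3 to compound 4 (2.26 log units; beyond the scatter), and on the other core it gave an at least 370-fold higher number from compound 2 to compound 1 (2.57 log units; beyond the scatter), so the direction of the step and its place beyond the scatter carry over between these two cores. Compound 4 gives > 371000 ug/mL, which is a limit and not a number: the limit of > 371000 ug/mL in this assay, at which 1 of the 4 values shown sits. Both steps are therefore lower bounds, and this pair does not show whether the change is equally large on the two cores: the limit of > 314000 ug/mL in this assay, at which 1 of the 4 values shown sits.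

The compounds shown leave open whether the step would carry over to a third core, or to a chain ending in an amine or a carboxylic acid in place of the present chain end. On these data alone, a shorter chain is also open, so the chain length at which the large step sets in remains unknown.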